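Phenyl for indolyl on a triazole-linked chain

The compounds below may be only part of what the source reports. "The series", "measured", "known", "first", "only" and "open" are said of these compounds alone.

Of the compounds shown here, three have been measured in an in vitro assay on LLC-PK1 cells for displacement of a labelled ligand from growth hormone secretagogue receptor type 1 (Homo sapiens); a higher number here means a weaker inhibitor, a lower number a stronger inhibitor. Compound 1 `O=C(N[C@H](c1c[nH]c2ccccc12)c1nnc(CCc2ccccc2)n1-c1ccccc1)c1ccccn1` gives 105 nM. Compound 2 `O=C(N[C@H](c1c[nH]c2ccccc12)c1nnc(CCc2c[nH]c3ccccc23)n1-c1ccccc1)c1ccccn1` gives 160 nM. Compound 3 `COc1ccc(Cn2c(CCc3c[nH]c4ccccc34)nnc2[C@H](NC(=O)Cc2ccncc2)c2c[nH]c3ccccc23)cc1` gives 76 nM. Compound 2 and compound 1 differ in one place, (phenyl in place of 1H-indol-3-yl on a saturated chain carbon, two bonds along the chain from an aromatic carbon), and the result is a 1.5-fold lower number from compound 2 to compound 1 (0.18 log units; within the scatter). The difference between the core of compound 3 and the core of compound 2 is not broken down here; compound 3 and compound 1 lie within the scatter of each other, while compound 3 and compound 2 do not.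

Compound 4 `COc1ccc(Cn2c(CCc3ccccc3)nnc2[C@H](NC(=O)Cc2ccncc2)c2c[nH]c3ccccc23)cc1` has not been measured. It differs from compound 3 in the same way, (phenyl in place of 1H-indol-3-yl on a saturated chain carbon, two bonds along the chain from an aromatic carbon), at the same place. Because the matching change in compound 2 to compound 1 gave a 1.5-fold lower number from compound 2 to compound 1 (0.18 log units; within the scatter), a step of similar size is expected for compound 4, which rests on a single pair. The step from compound 3 to compound 4 is estimated as a 1.4-fold lower number from compound 3 to compound 4 (0.14 log units; within the scatter). Compound 4 is therefore expected to give about 55 nM in this assay, with a likely range from 25 nM to 120 nM.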

Compound 4, half-maximal inhibitory concentration: 270 nM
The estimate for compound 4 lay 4.9-fold (0.69 log units) below the measured number, and the stated range ends below it.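

In this assay, putting phenyl in place of 1H-indol-3-yl on the core of compound 3 gave a 3.6-fold higher number from compound 3 to compound 4 (0.55 log units; beyond the scatter). The same change on the core of compound 1 stayed within the scatter, so in this series its effect did not carry over unchanged from one core to the other: the same change on two cores in this assay, a 1.5-fold lower number (0.18 log units; within the scatter) from compound 2 to compound 1 and a 3.6-fold higher number (0.55 log units; beyond the scatter) from compound 3 to compound 4, 5.4-fold (0.73 log units) apart, beyond the scatter of two such steps. Among these compounds, this rests on only two pairs, and it shows that the effect depends on the core, but not which part of the core is responsible or how the change would behave on any further core.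

The compounds shown leave open which of the parts that differ between the two cores accounts for the gap between the steps. They also leave open how the chain would fare with an amine or a carboxylic acid at its end in place of either aromatic group, or with a longer chain than the one in phenethyl and 2-(1H-indol-3-yl)ethyl.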